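The compounds below may be only part of what the source reports. "The series", "measured", "known", "first", "only" and "open" are said of these compounds alone.

The measured compounds:

Compound 1, `COc1ccc(/C=C/S(=O)(=O)Nc2c(F)c(F)c(F)c(F)c2F)cc1[N+](=O)[O-]`: 100000 nM
Compound 2, `COc1ccc(/C=C/S(=O)(=O)Nc2c(F)c(F)c(F)c(F)c2F)cc1N`: 35000 nM
Compound 3, `COc1ccc(NS(=O)(=O)/C=C/c2c(OC)cc(OCCCC(=O)O)cc2OC)cc1[N+](=O)[O-]`: 100000 nM

All three values come from a functional assay on DU-145 cells (Homo sapiens) for cytotoxicity, read by trypan blue exclusion, with a stated time of 96 h; a higher number here means a weaker inhibitor, a lower number a stronger inhibitor. Compound 1 and compound 2 share one core and differ in a single place, (amino in place of nitro on an aromatic carbon). That change gives a 2.9-fold lower number from compound 1 to compound 2 (0.46 log units; beyond the scatter). Compound 3 stands on a different core from compound 1, and the difference between the two cores is not broken down here; at the digits shown compound 3 sits level with compound 1, and together they carry the highest numbers of the three, with compound 2 the furthest away.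

Compound 4, `COc1ccc(NS(=O)(=O)/C=C/c2c(OC)cc(OCCCC(=O)O)cc2OC)cc1N`, has not yet been measured in this assay. It is made from compound 3 by amino in place of nitro on an aromatic carbon, which reads, one bond further out, as 4-methoxy-3-nitrophenyl turning into 3-amino-4-methoxyphenyl. The surroundings of the place match those of the change from compound 1 to compound 2 word for word, so this is the same change applied to the other core.

On that basis the step from compound 3 to compound 4 is expected to be a 2.5-fold lower number from compound 3 to compound 4 (0.40 log units; beyond the scatter), a size resting on compound 1 and compound 2 through a 2.9-fold lower number from compound 1 to compound 2 (0.46 log units; beyond the scatter). Whether the second core answers in the same way as the first is not known from these compounds alone. For compound 4 the estimate in this assay is 40000 nM, with a range from 15000 nM to 100000 nM.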

Compound 4, half-maximal inhibitory concentration: 10000 nM
Compound 4: middle estimate off by 4.0-fold (0.60 log units), on the high side; the whole stated range lies above it.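

In this assay, amino in place of nitro on the aromatic carbon lowers the number on the second core as well, giving a 10-fold lower number from compound 3 to compound 4 (1.00 log units; beyond the scatter). The direction of the change therefore carries from one core to the other in these two pairs, but its size does not: the same change on two cores in this assay, a 2.9-fold lower number (0.46 log units; beyond the scatter) from compound 1 to compound 2 and a 10-fold lower number (1.00 log units; beyond the scatter) from compound 3 to compound 4, 3.5-fold (0.54 log units) apart, beyond the scatter of two such steps. This shows that a step measured on one core did not give the size of the step on the other, yet two pairs do not show how the step would behave on any further core, and they do not show what in the cores sets the size.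

The compounds shown leave open whether a hydroxyl or an acetamide group at the same place, ortho to the methoxy group, would follow the amino group in direction and size on both cores. Going by these compounds, the two cores also differ from each other in more than one place, so it remains open which of those differences goes with the larger step, and whether a shorter or longer chain in place of the carboxylic acid chain of compound 4 would alter it.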